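Growth inhibition notes: cyclopentyloxy to cyclohexyloxy

A few compounds are considered here, and "the series" means these few. Any claim that something is new, unique, unknown or untested is made for them only; others in the source may bear on it.

Of the compounds shown here, three have been measured in a functional assay on M21 cells (Homo sapiens) for inhibition, read by sulforhodamine B assay, with a stated time of 48 h; on this read-out lower numbers stand for stronger inhibition of growth and higher numbers for weaker inhibition of growth. Compound 1 `c1cc(OC2CCCC2)ccc1NC1=NCCO1` gives 21100 nM, compound 2 `c1cc(NC2=NCCO2)cc(OC2CCCCC2)c1` gives 12000 nM, and compound 3 `O=C(CCl)NC(=O)Nc1cccc(OC2CCCC2)c1` gives 3500 nM. Compound 3 has the lowest number of the three, and its gaps to compound 2 and to compound 1 both lie beyond the scatter.

For the measured compounds named here, no two measured compounds differ in only one place, so the series offers no direct reading of a change in the ring on the oxygen. Compound 1 and compound 2 differ in more than that ring, and their two values cannot isolate it.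

Compound 4 `O=C(CCl)NC(=O)Nc1cccc(OC2CCCCC2)c1` keeps the rest of compound 3 and carries cyclohexyl in place of cyclopentyl on an oxygen on an aromatic ring. Going by the values given here, with no measured precedent for this change, no step beyond the scatter is expected in this assay, in either direction. The expectation is therefore anchored on compound 3 at 3500 nM. The estimated move is a 1.2-fold lower number from compound 3 to compound 4 (0.07 log units; within the scatter). For compound 4 the estimated value is 3000 nM, with an expected range from 1400 nM to 6500 nM.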

Compound 4, concentration for 50% growth inhibition: 2700 nM
Beside the measured number, compound 4's estimate is 1.1-fold (0.05 log units) above it; the range from low to high includes it.
By their numbers in this assay, from the lowest: compounds 4 and 3 (each within the scatter of the next); then compounds 2 and 1 (each within the scatter of the next).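

Notes on the series: in this assay the ring on the oxygen can now be read directly for the first time, and swapping cyclopentyl for cyclohexyl on an oxygen on an aromatic ring gives a 1.3-fold lower number from compound 3 to compound 4 (0.11 log units; within the scatter), so these two rings cannot be told apart at this position. With cyclohexyloxy held constant, the group on a nitrogen on an aromatic ring can also be read: replacing the five-membered ring group with the open-chain, chlorine-bearing group gives a 4.4-fold lower number from compound 2 to compound 4 (0.65 log units; beyond the scatter), a modest step and the only one so far that clears the scatter. No supporting data bear on either step, so the numbers stand without an explanation.

For the compounds shown here, what a methyl, a longer straight chain or a phenyl on the oxygen would give remains open, since only two carbon rings appear at that position here. Also open, going by these compounds, is whether the step at the nitrogen depends on the chlorine of the open-chain group, a question that hydrogen or bromine in its place would address.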